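A few compounds are considered here, and "the series" means these few. Any claim that something is new, unique, unknown or untested is made for them only; others in the source may bear on it.

The series shares one core, and in an ADME assay on microsomes from liver (Homo sapiens) for metabolic stability, with a stated time of 10 min (a higher number here means that more of the compound is left, a lower number that less of the compound is left), two of its members have been measured. Compound 1 `C[C@]1(C(=O)O)CC[C@H](C(=O)N2CC[C@](c3ccc(C(F)(C(F)(F)F)C(F)(F)F)cc3)(S(=O)(=O)c3ccc(F)cc3)C2)CC1` gives 97% in this assay. Compound 2 `COC[C@]1(C(=O)N2CC[C@](c3ccc(C(F)(C(F)(F)F)C(F)(F)F)cc3)(S(=O)(=O)c3ccc(F)cc3)C2)CC[C@H](C(=O)O)CC1` gives 100% in this assay, and the step of a number 3 percentage points higher from compound 1 to compound 2 (within the scatter) shows that exchanging one acid-bearing ring for another on the carbonyl carbon left the read-out unchanged. Compound 3 `O=C(N1CC[C@](c2ccc(C(F)(C(F)(F)F)C(F)(F)F)cc2)(S(=O)(=O)c2ccc(F)cc2)C1)C12CCC(C(=O)O)(CC1)OC2` gives "not determined" (no result reported) in this assay, so no number stands for it; its standing is therefore unknown, and the account rests on compounds 1 and 2 alone.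

Compound 4 `O=C(N1CC[C@](c2ccc(C(F)(C(F)(F)F)C(F)(F)F)cc2)(S(=O)(=O)c2ccc(F)cc2)C1)C1(O)CCS(=O)(=O)CC1` differs from compound 3 in one place: a group of 9 heavy atoms (5 carbon, 3 oxygen, 1 sulfur; one six-membered non-aromatic ring with 1 hetero atom) in place of a group of 11 heavy atoms (8 carbon, 3 oxygen; one six-membered non-aromatic ring of carbon only, one six-membered non-aromatic ring with 1 hetero atom), on a carbonyl carbon. For the measured compounds named here, no measured step covers this exchange directly. Going by the values given here, the only step on hand, from compound 1 to compound 2, lies within the scatter, and both of those compounds sit near the top of the read-out. On that thin basis compound 4 is expected to remain largely intact in this assay as well, with an estimated value of 90%, in a range from 70% to 100%.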

Compound 4, percent of the compound remaining: 100%
Compound 4: middle estimate off by 10 percentage points, on the low side; the range from low to high includes it.
By their numbers in this assay, from the lowest: compounds 1, 2 and 4 (each within the scatter of the next).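

Exchanging 4-carboxy-1-(methoxymethyl)cyclohexyl for 4-hydroxy-1,1-dioxothian-4-yl on the carbonyl carbon gives, in this assay, no change at the digits printed from compound 2 to compound 4 (within the scatter), and exchanging 4-carboxy-4-methylcyclohexyl for the same group gives a number 3 percentage points higher from compound 1 to compound 4 (within the scatter). The position therefore tolerates more than a swap between two carboxylic acid-bearing cyclohexyl groups: a group with a different ring and no carboxylic acid gives a read-out within the scatter of both. No measured evidence bears on why these groups read alike.

All three values lie close together near the top of the read-out, so the compounds shown do not reveal which group at this position, if any, would leave less of the compound remaining. On these data alone, whether an amine or an open alkyl chain on the carbonyl carbon would behave the same stays open.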